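Sulfonyl for amide on the pyrrolidine nitrogen

The compounds below may be only part of what the source reports. "The series", "measured", "known", "first", "only" and "open" are said of these compounds alone.

Compound 3 `CNC(=O)CN1CC[C@H](n2c(Nc3ccc(F)cc3)nc3cnc(Nc4ccc(N5CCN(C)CC5)cc4)nc32)C1` gives 1520 nM in a functional assay on HCC827 cells (Homo sapiens) for antiproliferative activity, read by MTT assay, with a stated time of 72 h (a higher number here means a weaker inhibitor, a lower number a stronger inhibitor), and stands highest of the three measured numbers. For the measured compounds named here, its nearest neighbour is compound 1 `CN1CCN(c2ccc(Nc3ncc4nc(Nc5ccc(F)cc5)n([C@H]5CCN(C(=O)CO)C5)c4n3)cc2)CC1`, with 380 nM; the only single-point step recorded, a 4.0-fold higher number from compound 1 to compound 3 (0.60 log units; beyond the scatter), is modest. Furthest away is compound 2 `CN1CCN(c2ccc(Nc3ncc4nc(Nc5ccccc5)n([C@H]5CCN(S(=O)(=O)C6CC6)C5)c4n3)cc2)CC1`, which carries the cyclopropylsulfonyl group on its ring nitrogen and gives 1.6 nM.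

Compound 4 `CN1CCN(c2ccc(Nc3ncc4nc(Nc5ccc(F)cc5)n([C@H]5CCN(S(=O)(=O)C6CC6)C5)c4n3)cc2)CC1` differs from compound 3 by cyclopropylsulfonyl in place of (methylcarbamoyl)methyl on an amine nitrogen in a ring. Going by the values given here, no measured step covers exactly this exchange, and the one step that does touch the same ring nitrogen, a 4.0-fold higher number from compound 1 to compound 3 (0.60 log units; beyond the scatter), is far smaller than the gap to compound 2. Compound 4 is nevertheless expected to fall well below compound 3 because compound 2 bearing the same cyclopropylsulfonyl group gives 1.6 nM, and the expected step is a 510-fold lower number from compound 3 to compound 4 (2.70 log units; beyond the scatter). Compound 4 is therefore estimated at 3 nM, in a range from 1 nM to 15 nM.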

Compound 4, half-maximal inhibitory concentration: 7.5 nM
The estimate for compound 4 lay 2.5-fold (0.40 log units) below the measured number, within the range that was stated.
By their numbers in this assay, from the lowest: compound 2; then compound 4; then compound 1; then compound 3.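

In this assay, the ring nitrogen now has direct readings for the cyclopropylsulfonyl group: it replaces (methylcarbamoyl)methyl with a large step (a 200-fold lower number from compound 3 to compound 4 (2.31 log units; beyond the scatter)) and (hydroxymethyl)carbonyl with another large step (a 51-fold lower number from compound 1 to compound 4 (1.70 log units; beyond the scatter)), and both far exceed the modest step between those two groups (a 4.0-fold higher number from compound 1 to compound 3 (0.60 log units; beyond the scatter)). Fluoro in place of hydrogen on an aromatic carbon also has its own reading, and this step (a 4.7-fold higher number from compound 2 to compound 4 (0.67 log units; beyond the scatter)) is much smaller than either change at the ring nitrogen. No evidence is available that explains the size of these steps.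

From the compounds shown here alone, it remains open whether a methylsulfonyl or phenylsulfonyl group on the ring nitrogen would behave like cyclopropylsulfonyl. Going by these compounds, it is also open whether chloro or methoxy on that aromatic carbon would match fluoro or hydrogen.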